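This account rests on a few compounds, and the source may have more. Where it says the series, first, only, none or still open, it means among the compounds named here.

In a functional assay on PC-3 cells (Homo sapiens) for cytotoxicity, read by WST assay, with a stated time of 48 h (a lower number here means a stronger inhibitor, a higher number a weaker inhibitor), compound 3 `N#C/C(=C\c1c[nH]c2cc(F)ccc12)C(=O)c1c[nH]c2ccccc12` gives > 50000 nM, which is a limit of the assay and not a number. Compound 4 `COc1ccc2c(/C=C(\C#N)C(=O)c3c[nH]c4ccccc34)c[nH]c2c1` differs from it in a single group: methoxy in place of fluoro on an aromatic carbon. The same swap, methoxy in place of fluoro on an aromatic carbon, occurs at another place in the molecule when compound 1 `COc1ccc2c(/C=C(\C#N)C(=O)c3c[nH]c4cc(F)ccc34)c[nH]c2c1`, at 21400 nM, is compared with compound 2 `COc1ccc2c(/C=C(\C#N)C(=O)c3c[nH]c4cc(OC)ccc34)c[nH]c2c1`, at 27000 nM. That measured step, a 1.3-fold higher number from compound 1 to compound 2 (0.10 log units; within the scatter), stays within the scatter. For the measured compounds named here, it is the only guide available, so no large change is expected, although the limit leaves the starting point open. The estimated step is an at least 1.2-fold lower number from compound 3 to compound 4 (0.09 log units; that floor lies within the scatter). For compound 4 the expected value is 40000 nM, with an estimated range of 20000 nM to 80000 nM.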

Compound 4, half-maximal inhibitory concentration: 12500 nM
Beside the measured number, compound 4's estimate is 3.2-fold (0.51 log units) above it, and the stated range ends above it.
By their numbers in this assay, from the lowest: compounds 4, 1 and 2 (each within the scatter of the next, the first and the last beyond it). At a limit, above all of these: compound 3.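

In this assay, methoxy in place of fluoro on an aromatic carbon gives an at least 4.0-fold lower number from compound 3 to compound 4 (0.60 log units; beyond the scatter), so this swap does not read the same at the two places: the same change on two cores in this assay, a 1.3-fold higher number (0.10 log units; within the scatter) from compound 1 to compound 2 and an at least 4.0-fold lower number (0.60 log units; beyond the scatter) from compound 3 to compound 4, at least 5.0-fold (0.70 log units) apart, beyond the scatter of two such steps. Compound 3 stands at a limit of the assay and not at a number, so that step has only a floor: the limit of > 50000 nM in this assay, at which 1 of the 4 values shown sits. Hydrogen in place of methoxy gives a 2.2-fold lower number from compound 2 to compound 4 (0.33 log units; beyond the scatter), and hydrogen in place of fluoro gives a 1.7-fold lower number from compound 1 to compound 4 (0.23 log units; within the scatter).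

Going by these compounds, whether an amine or a carboxylic acid at this position would shift the number remains open. On these data alone, the full size of the step from compound 3 also stays open.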